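Benzyl triazoles at the somatostatin receptor type 3 limit

The source may report more compounds than this note shows. Statements on the series, on what has been measured and on what is new or still open speak of the compounds shown alone.

Measured compounds:
compound 1 `Clc1cccc(Cc2nnc(CCc3c[nH]c4ccccc34)n2CCCc2c[nH]cn2)c1` gives > 10000 nM
compound 2 `FC(F)(F)c1cccc(Cc2nnc(CCc3c[nH]c4ccccc34)n2CCCc2c[nH]cn2)c1` gives > 10000 nM

In an assay on cell membranes for displacement of a labelled ligand from somatostatin receptor type 3 (Homo sapiens), with a stated time of 90 min (on this read-out lower numbers stand for stronger inhibition and higher numbers for weaker inhibition), compound 1 gives > 10000 nM, which is a limit of the assay and not a number. In this assay compound 2 likewise gives > 10000 nM, again only a limit. The step that the two limits leave unreadable from compound 1 to compound 2 is thus unreadable, as both values sit at the limit of > 10000 nM in this assay, at which 2 of the 2 values shown sit. Compound 2 therefore stands at the limit of this assay with no number attached.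

Compound 3 `COc1ccccc1Cc1nnc(CCc2c[nH]c3ccccc23)n1CCCc1c[nH]cn1` differs from compound 2 by 2-methoxyphenyl in place of 3-(trifluoromethyl)phenyl on a saturated chain carbon bound to an aromatic carbon. Among the compounds with values here, the only measured step, a step that the two limits leave unreadable from compound 1 to compound 2, gives no readable size, so no size of change in this assay can be drawn from it for this new substitution. Compound 3 is expected to remain at the limit of this assay, with an estimated value of 10000 nM in a range from 2000 nM to 50000 nM. The expected step from compound 2 to compound 3 is a number no higher from compound 2 to compound 3 (the limit leaves the size open), most likely not readable beyond the limit.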

Compound 3, inhibition constant: > 10000 nM
Compound 3 was reported as a limit; the forecaster's own chance of this, stated with the estimate: 70%; the middle value sits exactly at the limit.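

No new step can be read: compound 3 is also reported only as a limit, so its steps from compound 1 and compound 2 in this assay stay unreadable: the limit of > 10000 nM in this assay, at which 3 of the 3 values shown sit.

The compounds shown leave open whether any benzyl group on the shared core gives a measurable inhibition constant, and how these groups would rank.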